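The source may report more compounds than this note shows. Statements on the series, on what has been measured and on what is new or still open speak of the compounds shown alone.

Compound 1 `O=C(Nc1cccc(-n2cc(-c3ccncc3)c(-c3cc(O)cc(Cl)c3)n2)c1)Nc1ccc(Cl)c(C(F)(F)F)c1` gives 30.6% in a functional assay on IGROV-1 cells (Homo sapiens) for inhibition, read by sulforhodamine B assay, with a stated time of 48 h, tested at 10 uM; a lower number here means a stronger effect, a higher number a weaker effect of the compound at the concentration tested. Compound 2 `COc1cc(Cl)cc(-c2nn(-c3cccc(NC(=O)Nc4ccc(Cl)c(C(F)(F)F)c4)c3)cc2-c2ccncc2)c1` differs from it by methyl in place of hydrogen on an oxygen on an aromatic ring, and in this assay compound 2 gives 30.2%, so the step is a number 0.4 percentage points lower from compound 1 to compound 2 (within the scatter). Compound 3 `O=C(Nc1cccc(-n2cc(-c3ccncc3)c(-c3cc(O)cc(Cl)c3)n2)c1)c1cc(C(F)(F)F)cc(C(F)(F)F)c1` rests on a different core, and the difference between the two cores is not broken down here; in this assay compound 3 gives 73%, the highest of the three numbers and beyond the scatter from both of the others. Compound 4 `COc1cc(Cl)cc(-c2nn(-c3cccc(NC(=O)c4cc(C(F)(F)F)cc(C(F)(F)F)c4)c3)cc2-c2ccncc2)c1` carries the same change on the core of compound 3, namely (methyl in place of hydrogen on an oxygen on an aromatic ring). Because the earlier step was a number 0.4 percentage points lower from compound 1 to compound 2 (within the scatter), the same change is expected to move compound 4 by only a number 1 percentage points lower from compound 3 to compound 4 (within the scatter). Compound 4 is therefore estimated at 72%, expected to fall between 58% and 86%.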

Compound 4, a percentage reported as activity, at one concentration (the size of the read-out at that concentration, not a potency): 100%
The estimate for compound 4 lay 28 percentage points below the measured number; measured number above the stated range.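

In this assay, the step from hydroxy to methoxy on the core of compound 3 is a number 27 percentage points higher from compound 3 to compound 4 (beyond the scatter), so the effect at the concentration tested is weaker with the methoxy group on this core. The same change therefore does not carry over with the same size between these two cores: the same change on two cores in this assay, a number 0.4 percentage points lower (within the scatter) from compound 1 to compound 2 and a number 27 percentage points higher (beyond the scatter) from compound 3 to compound 4, 27.4 percentage points apart, beyond the scatter of two such steps. This rests on a single pair for each core, and it does not show why the two steps differ or what the change would do on any further core.

The compounds shown leave open how an ethyl group or a longer chain on that oxygen would read on either core. They also leave open what an amine in place of the hydroxy group would do.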